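Replacing the aminoethyl amide with a trifluoromethylphenyl group

The compounds below may be only part of what the source reports. "The series", "measured", "known", "first", "only" and "open" are said of these compounds alone.

Measured compounds:
compound 1, `CCn1c(C(=O)NCCN(C)C)ccc1C(CC)(CC)c1ccc(OCC(=O)C(C)(C)C)c(C)c1`: 77 nM
compound 2, `CCn1c(C(=O)NCCN)ccc1C(CC)(CC)c1ccc(OCC(=O)C(C)(C)C)c(C)c1`: 120 nM
compound 3, `CCn1c(C(=O)NCCN)ccc1C(CC)(CC)c1ccc(OCC(O)C(C)(C)C)c(C)c1`: 10 nM

All three share one core and were tested in an assay on HL-60 cells for agonist activity at vitamin D3 receptor (Homo sapiens), read by microscopy, with a stated time of 96 h; on this read-out higher numbers stand for an effect only at larger amounts of compound and lower numbers for an effect already at smaller amounts. Compound 3 gives the lowest number of the three; its nearest neighbour is compound 1, then compound 2, and both gaps lie beyond the scatter. The step of a 1.6-fold higher number from compound 1 to compound 2 (0.19 log units; within the scatter) shows that changing the end of the amide chain from dimethylamino to amino made little difference, while the step of a 12-fold lower number from compound 2 to compound 3 (1.08 log units; beyond the scatter) shows a large gain on turning the carbonyl beside the tert-butyl group into an alcohol.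

Compound 4, `CCn1c(C(=O)Nc2cccc(C(F)(F)F)c2)ccc1C(CC)(CC)c1ccc(OCC(O)C(C)(C)C)c(C)c1`, keeps the alcohol of compound 3 but changes the amide side: 3-(trifluoromethyl)phenyl in place of 2-aminoethyl on an amide-type nitrogen. Going by the values given here, no measured pair tests this kind of change; the only step at the amide, from compound 1 to compound 2, altered just the chain end and stayed within the scatter, so it gives little guidance for swapping a small chain for an aromatic ring. Among the compounds with values here, because the single known step at this position, a 1.6-fold higher number from compound 1 to compound 2 (0.19 log units; within the scatter), was small, compound 4 is expected to stay in the range of compound 3, with wide uncertainty: the expected step is a 2.0-fold higher number from compound 3 to compound 4 (0.30 log units; within the scatter), giving an estimate of 20 nM for compound 4, between 5 nM and 100 nM.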

Compound 4, half-maximal effective concentration: > 50000 nM
Compound 4: a limit, no number (the forecaster's own chance of this, stated with the estimate: 5%); middle value at least 2500-fold (3.39 log units) from the limit.
By their numbers in this assay, from the lowest: compound 3; then compounds 1 and 2 (each within the scatter of the next). At a limit, above all of these: compound 4.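

The amide nitrogen is far less forgiving than the earlier change at the end of the chain suggested: in this assay, 3-(trifluoromethyl)phenyl in place of 2-aminoethyl gives an at least 5000-fold higher number from compound 3 to compound 4 (3.69 log units; beyond the scatter) and so produces the largest step seen in this series. Compound 4 also keeps the alcohol that accompanied the low number of compound 3, so this alcohol is not enough on its own, and what sits on the amide nitrogen matters as well. The result for compound 4 is a limit of the assay and not a number: the limit of > 50000 nM in this assay, at which 1 of the 4 values shown sits.

Compound 4 is the only compound here with an aromatic ring on the amide nitrogen, so the compounds shown cannot separate the effect of the ring from that of its trifluoromethyl group, or from the loss of the amine at the end of the chain. They also leave open how a plain phenyl ring, a longer chain such as 3-aminopropyl, or a chain ending in a carboxylic acid would behave at this nitrogen.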